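A cyano group in place of methyl in compound 2

This account rests on a few compounds, and the source may have more. Where it says the series, first, only, none or still open, it means among the compounds named here.

compound 1 `Cc1ccc(S(=O)(=O)N2C/C(=C\c3ccncc3)C(=O)/C(=C/c3ccccc3F)C2)cc1`: 9700 nM
compound 2 `Cc1ccc(S(=O)(=O)N2C/C(=C\c3ccncc3)C(=O)/C(=C/c3ccccc3C(F)(F)F)C2)cc1`: 4640 nM

For the measured compounds named here, in a functional assay on HepG2 cells (Homo sapiens) for cytotoxicity, read by MTT assay, with a stated time of 24 h (on this read-out higher numbers stand for weaker inhibition and lower numbers for stronger inhibition), compound 2 gives 4640 nM, the lower of the two numbers so far, while compound 1 gives 9700 nM. The next compound, compound 3 `N#Cc1ccc(S(=O)(=O)N2C/C(=C\c3ccncc3)C(=O)/C(=C/c3ccccc3C(F)(F)F)C2)cc1`, differs from compound 2 in one place: cyano in place of methyl on an aromatic carbon. This is cyano in place of methyl on an aromatic carbon, para to a large group, turning 4-methylphenyl into 4-cyanophenyl. Going by the values given here, only one measured step exists, a 2.1-fold lower number from compound 1 to compound 2 (0.32 log units; beyond the scatter), a modest one that exchanges fluoro for trifluoromethyl at a different group. Among the compounds with values here, no measured step involves the methyl or the cyano group, so the data give no direct guide to this change. In this assay, no shift beyond the scatter is expected in either direction. The expected change is a 1.1-fold lower number from compound 2 to compound 3 (0.04 log units; within the scatter). For compound 3 the estimated value is 4200 nM, with an expected range of 1800 nM to 9500 nM.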

Compound 3, half-maximal inhibitory concentration: 5920 nM
Compound 3: the middle estimate sits 1.4-fold (0.15 log units) below what was measured; the measured number falls inside the stated range.
By their numbers in this assay, from the lowest: compounds 2, 3 and 1 (each within the scatter of the next, the first and the last beyond it).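

In this assay the move from (4-methylphenyl)sulfonyl to (4-cyanophenyl)sulfonyl gives a 1.3-fold higher number from compound 2 to compound 3 (0.11 log units; within the scatter) and so stays within the usual scatter. For the compounds shown here, this is the first measured change at this aromatic carbon, para to a large group, whereas the earlier step concerned a different group. A cyano group can therefore stand in place of methyl here without a shift beyond the scatter on this read-out, and the swap adds a hydrogen-bond acceptor and one heavy atom. No measurement is available that accounts for this result.

From the compounds shown here alone, whether an amine or a carboxylic acid on this aromatic carbon would also leave the number unmoved remains open. Going by these compounds, it is also open whether cyano in place of methyl would give the same result with fluoro instead of trifluoromethyl on the other aromatic ring, as in compound 1.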